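Swapping the Acid for a Methyl Ester

A few compounds are considered here, and "the series" means these few. Any claim that something is new, unique, unknown or untested is made for them only; others in the source may bear on it.

compound 1 `C=C/C(C)=C\CC/C(C)=C/c1cc(C(=O)O)co1` gives 89300 nM
compound 2 `C=C/C(C)=C/CC/C(C)=C/c1cc(C(=O)O)co1` gives 89700 nM
compound 3 `C=C/C(C)=C\CC/C(C)=C/c1cc(C(=O)OC)co1` is not yet measured

In a functional assay on A549 cells (Homo sapiens) for cytotoxicity, read by MTT assay, with a stated time of 48 h (on this read-out lower numbers stand for stronger inhibition and higher numbers for weaker inhibition), compound 1 gives 89300 nM and stands level with compound 2 within the scatter. Their step of a 1.0-fold higher number from compound 1 to compound 2 (0.00 log units; within the scatter) rests on the fact that compounds 1 and 2 differ only in the configuration as drawn and so gives no direct measure for the next change. Compound 3 carries methyl in place of hydrogen on an oxygen next to a carbonyl group in the change carboxy to methoxycarbonyl: methyl in place of hydrogen on an oxygen next to a carbonyl group. With no measured guide, no step beyond the scatter is expected in this assay and the estimated change is a 1.3-fold lower number from compound 1 to compound 3 (0.11 log units; within the scatter) in this expectation. Compound 3 is estimated at 70000 nM with 25000 nM to 150000 nM as its expected range.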

Compound 3, half-maximal inhibitory concentration: 89600 nM
Compound 3: middle estimate off by 1.3-fold (0.11 log units), on the low side, within the range that was stated.
By their numbers in this assay, from the lowest: compounds 1, 3 and 2 (each within the scatter of the next).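

Replacing the hydrogen on the oxygen of the carboxy group with methyl, which gives methoxycarbonyl, is the only change at this position among these compounds, and in this assay it gives a 1.0-fold higher number from compound 1 to compound 3 (0.00 log units; within the scatter). At this position, then, the acid and its methyl ester read alike, with no step beyond the scatter. The earlier step could not show this: the fact that compounds 1 and 2 differ only in the configuration as drawn

From the compounds shown here alone, whether an ethyl or benzyl group on that oxygen, or an amide in place of the ester, would read the same remains open. So does the methyl ester carrying the double-bond configuration drawn in compound 2.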